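The source may hold more compounds than are shown below. What is called first, only, known or untested is meant among the compounds shown, and "the series" means these compounds.

Measured compounds:
- compound 1 `CC/C(C)=N\NC(=S)N(Cc1ccccc1)Cc1ccccc1` — an ADME assay on Vero cells (Chlorocebus sabaeus) for cytotoxicity, read by MTT assay, with a stated time of 72 h; a higher number here means that more compound is tolerated, a lower number that less compound is tolerated: "not determined" (no result reported)
- compound 2 `S=C(N/N=C\c1ccccc1)N(Cc1ccccc1)Cc1ccccc1` — this assay: 174000 nM

From the compounds shown here alone, compound 1 stands without a number of its own: in this assay no result was obtained for it, so its tolerated concentration is unknown. The only point of reference in the series is a close relative sharing the core of compound 1; in this assay compound 2 gives 174000 nM, a concentration at which the cells still tolerate a good deal of material.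

Compound 3 `C/C(=N/NC(=S)N(Cc1ccccc1)Cc1ccccc1)c1ccc([N+](=O)[O-])cc1` is yet to be measured. The change from compound 1 to compound 3 is 4-nitrophenyl in place of ethyl on a carbon with a double bond to nitrogen. Among the measured compounds shown here, no measured pair bounds this step, so its size cannot be read from the data; the expectation rests on compound 2 alone. Given that compound 2 gives 174000 nM, compound 3 is expected to land in a similar region, with the change possibly shifting the tolerated concentration somewhat lower, but not clearly beyond the usual scatter. Compound 3 is therefore estimated at 100000 nM in this assay, within a range of 30000 nM to 300000 nM.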

Compound 3, half-maximal cytotoxic concentration: < 150000 nM
Compound 3: only a limit was reported (the forecaster's own chance of this, stated with the estimate: 20%); the middle value lies beyond the limit too.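

No step can be read from compound 1 to compound 3 in this assay, as compound 1 stands without a number there. Compound 3 gives only a limit of the assay, < 150000 nM. Left open is how far the tolerated concentration moves when 4-nitrophenyl takes the place of ethyl on the carbon with a double bond to nitrogen.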